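Chloro on the pendant ring of compound 2

The source may report more compounds than this note shows. Statements on the series, on what has been measured and on what is new or still open speak of the compounds shown alone.

Of the compounds shown here, two of a shared core have been tested in a functional assay on the whole organism (strain albino) for inhibition, with Rattus norvegicus as the target, read by paw edema, with a stated time of 1 h, at a dose of 100 mg/kg by the oral route; a higher number here means more inhibition at the dose given (going by the name of the read-out), a lower number less inhibition. Compound 1, `N#Cc1c(-c2ccc(Cl)cc2)nc(SCC(=O)Nn2c(COc3ccc(Cl)cc3Cl)nc3ccccc3c2=O)[nH]c1=O`, gives 63.6% in this assay. Compound 2, `O=C(CSc1nc(-c2ccccc2)c(C(=O)O)c(=O)[nH]1)Nn1c(COc2ccc(Cl)cc2Cl)nc2ccccc2c1=O`, gives 69.1% in this assay. The gap between compound 2 and compound 1 is within the usual scatter, so the two numbers cannot be told apart, and neither can be said to give the higher inhibition in this assay. Compound 2 is thus a reasonable starting point for a single change.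

Compound 3, `O=C(CSc1nc(-c2ccc(Cl)cc2)c(C(=O)O)c(=O)[nH]1)Nn1c(COc2ccc(Cl)cc2Cl)nc2ccccc2c1=O`, has not yet been measured. It differs from compound 2 in one place: chloro in place of hydrogen on an aromatic carbon. For the measured compounds named here, no pair of measured compounds differing in exactly this one place exists here, so the size of the step has to be judged from the whole picture. Compound 1 already carries the 4-chlorophenyl group and lands within scatter of compound 2, which suggests that the chloro on its own does little in this assay. The step from compound 2 to compound 3 is therefore expected to be a number 2.1 percentage points lower from compound 2 to compound 3 (within the scatter), that is, nothing beyond the scatter. Compound 3 is expected to give about 67% in this assay, with a range from 55% to 78%.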

Compound 3, a percentage reported as inhibition, in the whole organism at one dose (the size of the read-out at that dose, not a potency): 58.2%
The estimate for compound 3 lay 8.8 percentage points above the measured number; the range from low to high includes it.
By their numbers in this assay, from the lowest: compounds 3, 1 and 2 (each within the scatter of the next, the first and the last beyond it).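

In this assay the change from phenyl to 4-chlorophenyl gives a number 10.9 percentage points lower from compound 2 to compound 3 (beyond the scatter) and so the pendant ring is a place where one added chlorine can move the read-out, though the step is modest and comes from a single pair at a single dose. The second pair adds a different point, since the swap on the other ring gives a number 5.4 percentage points lower from compound 1 to compound 3 (within the scatter) and so, with the 4-chlorophenyl group in place, carboxy and cyano cannot be told apart in this measure. Nothing available here accounts for the lower number that comes with the chlorine.

Still open, as far as these compounds go, is whether the step belongs to chlorine itself or would also appear with another group in the same place, such as fluoro, methyl or methoxy. Also open, from the compounds shown here alone, is whether adding chloro would lower the number to a similar extent on a phenyl compound carrying cyano rather than carboxy, which would show whether the step holds beyond this one pair.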